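The compounds below may be only part of what the source reports. "The series", "measured", "known", "first", "only" and "open" are said of these compounds alone.

Measured compounds in an assay on isolated protein for inhibition of proto-oncogene tyrosine-protein kinase receptor Ret (Homo sapiens), read by radiometric assay and 33P incorporation, in the presence of a further agent that is not named here; a higher number here means a weaker inhibitor, a lower number a stronger inhibitor:
- compound 1, `CCc1cc(-c2nn(C(C)C)c3ncnc(N)c23)no1`, gives 41 nM
- compound 3, `CC(C)n1nc(-c2cc(-c3ccc(F)cc3)on2)c2c(N)ncnc21`, gives 150 nM
- compound 2, `CC(C)n1nc(/C=N/O)c2c(N)ncnc21`, gives 4900 nM

Compound 3 stands second highest of the three numbers in this assay: nearest to it is compound 1, beyond the scatter, and furthest is compound 2, which shows a much higher number. For the measured compounds named here, the one step bearing on the present change is a 3.7-fold higher number from compound 1 to compound 3 (0.56 log units; beyond the scatter), where the smaller group on that aromatic carbon went with the lower number.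

Compound 4, `CC(C)n1nc(-c2ccon2)c2c(N)ncnc21`, differs from compound 3 by hydrogen in place of 4-fluorophenyl on an aromatic carbon

Going by the values given here, no measured step removes a group from this carbon entirely, so the direction of the step is uncertain. The step from compound 1 to compound 3 suggests that a smaller group at this position need not raise the number, while compound 2, which lacks the five-membered ring altogether, shows that much can be lost around this part of the core. The expected step is therefore small, a 1.3-fold higher number from compound 3 to compound 4 (0.12 log units; within the scatter), with wide bounds. Compound 4 is expected to give about 200 nM in this assay, within a range of 60 nM to 700 nM.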

Compound 4, half-maximal inhibitory concentration: 213 nM
Compound 4: middle estimate off by 1.1-fold (0.03 log units), on the low side, and the stated range covers the measured number.
By their numbers in this assay, from the lowest: compound 1; then compounds 3 and 4 (each within the scatter of the next); then compound 2.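

In this assay, hydrogen on this carbon of the five-membered aromatic ring stays within the scatter of 4-fluorophenyl (a 1.4-fold higher number from compound 3 to compound 4 (0.15 log units; within the scatter)), so the seven heavy atoms of that group are not required to hold the level of compound 3. Ethyl is the only group here that separates from hydrogen beyond the scatter (a 5.2-fold higher number from compound 1 to compound 4 (0.72 log units; beyond the scatter)), while even the unsubstituted ring goes with a large step over the open chain of compound 2 (a 23-fold lower number from compound 2 to compound 4 (1.36 log units; beyond the scatter)). Nothing available gives a reason for any of these steps.

Open, from the compounds shown here alone, is whether the advantage of ethyl over hydrogen extends to methyl, propyl or a longer chain. Also open, going by these compounds, is how an amine or a carboxylic acid on this carbon would compare with hydrogen.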